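Swapping thiophen-2-yl for pyridin-2-yl in compound 3

The compounds below may be only part of what the source reports. "The series", "measured", "known", "first", "only" and "open" are said of these compounds alone.

In a functional assay on HCT-15 cells (Homo sapiens) for cytotoxicity, read by CCK-8 assay (a higher number here means a weaker inhibitor, a lower number a stronger inhibitor), compound 1 (`Oc1cccc(-c2cc(-c3cccs3)cc(-c3ccccc3O)n2)c1`) gives > 50000 nM as a limit of the assay and not a number. Compound 2 (`Oc1ccc(-c2cc(-c3cccs3)cc(-c3ccccc3O)n2)cc1`) gives > 50000 nM as a limit too. Going by the values given here, compound 3 (`Oc1ccc(-c2cc(-c3cccs3)cc(-c3cccc(O)c3)n2)cc1`) gives 1770 nM and so holds the only true number so far.

Compound 4 (`Oc1ccc(-c2cc(-c3ccccn3)cc(-c3cccc(O)c3)n2)cc1`) has pyridin-2-yl in place of thiophen-2-yl on an aromatic carbon, opposite the ring nitrogen (pyridin-2-yl in place of thiophen-2-yl on an aromatic carbon).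

The readable measured steps are large, namely an at least 28-fold lower number from compound 1 to compound 3 (1.45 log units; beyond the scatter) and also an at least 28-fold lower number from compound 2 to compound 3 (1.45 log units; beyond the scatter) as hydroxyphenyl groups are exchanged. The thiophen-2-yl stays in place in all of them, so none of them tests this swap directly. The expectation in this assay therefore starts from compound 3 at 1770 nM and foresees no step beyond the scatter. The expected change is a 1.4-fold higher number from compound 3 to compound 4 (0.15 log units; within the scatter) and this estimate is a loose one. For compound 4 the estimated value is 2500 nM with the expected range running from 600 nM to 10000 nM at its two ends.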

Compound 4, half-maximal inhibitory concentration: > 50000 nM
Compound 4: a limit, no number; the forecaster's own chance of this, stated with the estimate: 15%; middle value at least 20-fold (1.30 log units) away from the limit.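

Going by these compounds alone, this is the first direct test of the group at this position, opposite the ring nitrogen, and in this assay the exchange of thiophen-2-yl for pyridin-2-yl brings an at least 28-fold higher number from compound 3 to compound 4 (1.45 log units; beyond the scatter). Both hydroxyphenyl groups stay the same, so this single exchange accounts for the whole step, whereas the earlier compounds all kept thiophen-2-yl and showed only what exchanging the hydroxyphenyl groups does. Compound 4 gives a limit and not a number, so the step is a minimum and its true size stays unknown, and this limit recurs across the series: the limit of > 50000 nM in this assay, at which 3 of the 4 values shown sit.

The compounds shown leave open whether furan-2-yl, phenyl or a simple amine at this position would keep the activity of compound 3. Also open, going by these compounds, is whether pyridin-3-yl would behave like pyridin-2-yl, which would help separate the effect of the ring as a whole from that of the place of its nitrogen.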